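The compounds below may be only part of what the source reports. "The series", "measured", "known", "first", "only" and "open" are said of these compounds alone.

In an ADME assay on TZM cells (Homo sapiens) for cytotoxicity, read by XTT assay, with a stated time of 4 days (a higher number here means that more compound is tolerated, a lower number that less compound is tolerated), compound 1 (`Cc1cc(C#N)cc(C)c1Oc1ccc(N)c(Nc2ccc(C#N)cc2)n1`) gives 8980 nM, compound 2 (`Cc1cc(Br)cc(C)c1Oc1ccc(N)c(Nc2ccc(C#N)cc2)n1`) gives 15500 nM and compound 3 (`C=CCc1cc(C)c(Oc2ccc(N)c(Nc3ccc(C#N)cc3)n2)c(C)c1`) gives 8460 nM. These three values lie within the usual scatter of one another, so compound 3 cannot be separated from the other two. Compound 4 (`Cc1cc(C#CC2CC2)cc(C)c1Oc1ccc(N)c(Nc2ccc(C#N)cc2)n1`) keeps the rest of compound 3 and changes one group, with 2-cyclopropylethynyl in place of allyl on an aromatic carbon. The measured steps at this same place bear directly on that change. They are a 1.7-fold higher number from compound 1 to compound 2 (0.24 log units; within the scatter), a 1.1-fold lower number from compound 1 to compound 3 (0.03 log units; within the scatter) and a 1.8-fold lower number from compound 2 to compound 3 (0.26 log units; within the scatter), and none of them exceeds the scatter. Among the measured compounds shown here, no measured compound carries 2-cyclopropylethynyl, however, so the new group itself remains untested. On this evidence, no step beyond the scatter is expected in this assay, and no direction can be favoured. The expected step is a 1.1-fold higher number from compound 3 to compound 4 (0.03 log units; within the scatter). For compound 4, the estimated value is 9000 nM, with an expected range from 4000 nM to 20000 nM.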

Compound 4, half-maximal cytotoxic concentration: 7450 nM
Beside the measured number, compound 4's estimate is 1.2-fold (0.08 log units) above it; the range from low to high includes it.
By their numbers in this assay, from the lowest: compounds 4, 3, 1 and 2 (each within the scatter of the next, the first and the last beyond it).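

Compound 4 shows that this position, on an aromatic carbon para to a large group, also tolerates 2-cyclopropylethynyl, with its three-membered ring and triple bond, and that the larger group of 5 heavy atoms leaves the reading in this assay close to those of the allyl and cyano compounds: there is a 1.1-fold lower number from compound 3 to compound 4 (0.06 log units; within the scatter) and a 1.2-fold lower number from compound 1 to compound 4 (0.08 log units; within the scatter), and both steps lie within the scatter. Among the compounds shown here, the one step that passes the scatter is modest, a 2.1-fold lower number from compound 2 to compound 4 (0.32 log units; beyond the scatter), so the new group can be told apart only from bromo. No measurement here explains these steps.

On these data alone, it remains open whether an amine or a carboxylic acid at this position would shift the tolerated concentration further. As far as these compounds go, it is equally open whether a longer chain ending in a hydroxyl group would do so.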